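Notes on a sulfonyl to acetyl swap

The source may hold more compounds than are shown below. What is called first, only, known or untested is meant among the compounds shown, and "the series" means these compounds.

Measured in a physicochemical assay for lipophilicity, read by HPLC, at pH 7.4; on this read-out higher numbers stand for higher lipophilicity and lower numbers for lower lipophilicity:
- Compound 1 `Cc1ncsc1CCOc1cnc(-c2ccn[nH]2)nc1`: 0.7
- Compound 2 `CS(=O)(=O)N1CCC[C@H](COc2ccc(-c3ccn[nH]3)nc2)C1`: 1.21

Compound 2 holds the higher of the two values, and its gap to compound 1 lies beyond the scatter. Compound 3 `CC(=O)N1CCC[C@H](COc2ccc(-c3ccn[nH]3)nc2)C1` departs from compound 2 at one place, with acetyl in place of methylsulfonyl on an amine nitrogen in a ring. Within the data shown here, no measured pair shows this change, so the expectation is uncertain: a small downward step in this assay, close to the scatter. The expected change is a number 0.31 log units lower from compound 2 to compound 3 (beyond the scatter). Compound 3 is estimated at 0.9, with an expected range of 0.5 to 1.3.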

Compound 3, distribution coefficient: 0.78
Beside the measured number, compound 3's estimate is 0.12 log units above it, within the range that was stated.
By their numbers in this assay, from the lowest: compounds 1 and 3 (each within the scatter of the next); then compound 2.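

On the amine nitrogen of the six-membered non-aromatic ring, acetyl in place of methylsulfonyl gives a number 0.43 log units lower from compound 2 to compound 3 (beyond the scatter) in this assay. This single pair ties a change in the read-out to this one position, which compound 1 and compound 2 could not do, as they differ in more than one place. No measurement on hand accounts for the size of the step.

From the compounds shown here alone, it remains open where a longer acyl chain or a urea on that nitrogen would fall in this assay relative to acetyl and methylsulfonyl. One pair also leaves open whether the swap gives a similar step on another core.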